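Swapping furan for pyrrole on the thiosemicarbazone arm

The source may report more compounds than this note shows. Statements on the series, on what has been measured and on what is new or still open speak of the compounds shown alone.

Compound 3 `CC1=CC[C@H](C(C)(C)NC(=S)N/N=C/c2ccco2)CC1` gives 13500 nM in a functional assay on PC-3 cells (Homo sapiens) for inhibition, read by sulforhodamine B assay, with a stated time of 48 h (on this read-out lower numbers stand for stronger inhibition of growth and higher numbers for weaker inhibition of growth), second highest of the three numbers. Compound 1 `CC1=CC[C@H](C(C)(C)NC(=S)NN)CC1` gives 44500 nM, and compound 2 `CC1=CC[C@H](C(C)(C)NC(=S)N/N=C/c2cccc(Cl)c2)CC1` gives 600 nM. The step of a 3.3-fold lower number from compound 1 to compound 3 (0.52 log units; beyond the scatter) shows that attaching the five-membered ring helps, while a 23-fold higher number from compound 2 to compound 3 (1.35 log units; beyond the scatter) shows how much the identity of the aryl group matters. Compound 4 `CC1=CC[C@H](C(C)(C)NC(=S)N/N=C/c2ccc[nH]2)CC1` carries 1H-pyrrol-2-yl in place of furan-2-yl on a carbon with a double bond to nitrogen. Within the data shown here, no measured step swaps one five-membered ring for another, so the expectation rests only on the aryl sensitivity seen in the step from compound 2. Compound 4 is therefore expected to land near compound 3, with a small step of a 1.4-fold lower number from compound 3 to compound 4 (0.13 log units; within the scatter), estimated at 10000 nM within 3000 nM to 40000 nM.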

Compound 4, concentration for 50% growth inhibition: 2800 nM
Compound 4: the middle estimate sits 3.6-fold (0.55 log units) above what was measured; the whole stated range lies above it.
By their numbers in this assay, from the lowest: compound 2; then compound 4; then compound 3; then compound 1.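

In this assay, the exchange of one five-membered ring for another at this carbon with a double bond to nitrogen is itself a real change (a 4.8-fold lower number from compound 3 to compound 4 (0.68 log units; beyond the scatter)), so the position separates furan-2-yl from 1H-pyrrol-2-yl and not only five-membered rings from 3-chlorophenyl. With 1H-pyrrol-2-yl, the distance to the 3-chlorophenyl group shrinks (a 4.7-fold higher number from compound 2 to compound 4 (0.67 log units; beyond the scatter)) and the gain over the bare arm grows (a 16-fold lower number from compound 1 to compound 4 (1.20 log units; beyond the scatter)). Nothing given here explains the difference between the two rings. From the compounds shown here alone, it remains open where thiophen-2-yl or 1-methyl-1H-pyrrol-2-yl would fall relative to these two rings.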